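This account rests on a few compounds, and the source may have more. Where it says the series, first, only, none or still open, it means among the compounds named here.

Measured in a functional assay on cells (Lymphocyte, Homo sapiens); on this read-out higher numbers stand for weaker inhibition and lower numbers for stronger inhibition:
Compound 1, `Nc1nc(N2CCN(C(=O)COc3ccc(Cl)cc3)CC2)c2nc(Cc3ccc(F)cc3)sc2n1`: 700 nM
Compound 2, `Nc1nc(N2CCN(C(=O)COc3ccc(Cl)cc3)CC2)c2nc(CCc3ccc(F)cc3)sc2n1`: 4400 nM
Compound 3, `Nc1nc(N2CCN(C(=O)COc3ccc(Cl)cc3)CC2)c2nc(CCCc3ccc(F)cc3)sc2n1`: 960 nM

Compound 3 stands second highest of the three numbers. Its nearest neighbour is compound 1, with a 1.4-fold higher number from compound 1 to compound 3 (0.14 log units; within the scatter), a gap within the scatter; its furthest is compound 2, with a 4.6-fold lower number from compound 2 to compound 3 (0.66 log units; beyond the scatter).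

Compound 4, `Cc1ccc(-c2nc3c(N4CCN(C(=O)COc5ccc(Cl)cc5)CC4)nc(N)nc3s2)cc1`, has not yet been measured. It differs from compound 3 by 4-methylphenyl in place of 3-(4-fluorophenyl)propyl on an aromatic carbon. The three measured steps all alter only the length of the saturated chain between the shared core and the 4-fluorophenyl group: a 6.3-fold higher number from compound 1 to compound 2 (0.80 log units; beyond the scatter), a 4.6-fold lower number from compound 2 to compound 3 (0.66 log units; beyond the scatter) and a 1.4-fold higher number from compound 1 to compound 3 (0.14 log units; within the scatter). None of them removes the chain altogether or exchanges the fluorine for a methyl, so they bear on the new step only in showing that this position tolerates change with modest and non-monotonic effects. On that basis a step of about a 1.0-fold higher number from compound 3 to compound 4 (0.02 log units; within the scatter) is expected, with its direction uncertain. Compound 4 is therefore estimated at 1000 nM in this assay, within a range of 250 nM to 4000 nM.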

Compound 4, half-maximal inhibitory concentration: 350 nM
Estimate against measurement, compound 4: 2.9-fold (0.46 log units) above, within the range that was stated.
By their numbers in this assay, from the lowest: compounds 4, 1 and 3 (each within the scatter of the next, the first and the last beyond it); then compound 2.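

In this assay, the aromatic carbon next to the ring nitrogen and the ring sulfur carries an aryl group with no saturated chain at all, and activity is kept: 4-methylphenyl in place of 3-(4-fluorophenyl)propyl gives a 2.7-fold lower number from compound 3 to compound 4 (0.44 log units; beyond the scatter) and in place of 2-(4-fluorophenyl)ethyl gives a 13-fold lower number from compound 2 to compound 4 (1.10 log units; beyond the scatter) as the largest step in the set. Against 4-fluorobenzyl, the change gives a 2.0-fold lower number from compound 1 to compound 4 (0.30 log units; within the scatter) and so separates neither compound from the other. No measurement shown here accounts for any of these steps.

As far as these compounds go, compound 4 differs from the others in both chain and ring substituent, so what remains open is how 4-fluorophenyl itself would behave on this carbon. Also open, from the compounds shown here alone, is whether an amine or a carboxylic acid on the ring would be tolerated here.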